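This account rests on a few compounds, and the source may have more. Where it says the series, first, only, none or still open, it means among the compounds named here.

Three compounds of the series carry numbers in a functional assay on T47D cells (Homo sapiens) for cytotoxicity, read by sulforhodamine B assay, with a stated time of 48 h; on this read-out higher numbers stand for weaker inhibition and lower numbers for stronger inhibition. Compound 1 `CN(C)/C=C/C(=O)c1cc2ccccc2oc1=O` gives 147000 nM. Compound 2 `Cc1nnc(NS(=O)(=O)c2ccc(N/C=C\C(=O)c3cc4ccccc4oc3=O)cc2)s1` gives 94000 nM, and compound 3 `O=C(/C=C\Nc1ccc(S(=O)(=O)Nc2ncccn2)cc1)c1cc2ccccc2oc1=O` gives 75200 nM. Compound 2 stands second highest of the three; its nearest neighbour is compound 3 and its furthest is compound 1, and both gaps lie within the scatter, so none of the three can be set apart from the others on these numbers.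

Compound 4 `COc1cnc(NS(=O)(=O)c2ccc(N/C=C\C(=O)c3cc4ccccc4oc3=O)cc2)nc1` has not been measured. It differs from compound 2 in one place: 5-methoxypyrimidin-2-yl in place of 5-methyl-1,3,4-thiadiazol-2-yl on a sulfonamide nitrogen. Among the measured compounds shown here, one measured step bears on this exchange, the one at the same sulfonamide nitrogen, a 1.3-fold lower number from compound 2 to compound 3 (0.10 log units; within the scatter), in which the same five-membered ring gave way to a pyrimidin-2-yl and the number moved by less than the scatter. For the measured compounds named here, the methoxy group carried by the entering ring of compound 4 is not covered by any measured pair, and no further steps are available. The step from compound 2 to compound 4 is therefore expected to stay within the scatter, a 1.1-fold lower number from compound 2 to compound 4 (0.04 log units; within the scatter), with no direction that can be called beyond it. For compound 4 the expected value in this assay is 85000 nM, with a range from 40000 nM to 180000 nM.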

Compound 4, half-maximal inhibitory concentration: 8800 nM
Compound 4: the middle estimate sits 9.7-fold (0.98 log units) above what was measured; the measured number lies below the stated range.
By their numbers in this assay, from the lowest: compound 4; then compounds 3, 2 and 1 (each within the scatter of the next).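

In this assay the exchange on the sulfonamide nitrogen gives an 11-fold lower number from compound 2 to compound 4 (1.03 log units; beyond the scatter) and so shows that this position can move the number beyond the scatter, which the earlier exchange there, with a 1.3-fold lower number from compound 2 to compound 3 (0.10 log units; within the scatter) as its step, did not show. Methoxy in place of hydrogen on an aromatic carbon gives an 8.5-fold lower number from compound 3 to compound 4 (0.93 log units; beyond the scatter) in this same setting, so within this small set the shift beyond the scatter appears only where 5-methoxypyrimidin-2-yl sits on the sulfonamide nitrogen, while pyrimidin-2-yl and 5-methyl-1,3,4-thiadiazol-2-yl remain within the scatter of each other. No measurement shown gives a reason for the size of this step, and the explanation remains unsupported by any data here.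

Going by these compounds, whether an ethoxy group, a hydroxy group, an amine or a chlorine atom in place of the methoxy would keep the lower number remains open. The methoxy step also rests on a single pair, so it is not known whether it would carry over to another ring on the sulfonamide nitrogen.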